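Chloro to methoxy on a fused benzotriazole core

The source may report more compounds than this note shows. Statements on the series, on what has been measured and on what is new or still open speak of the compounds shown alone.

Compound 1 `Brc1ccc(Cn2nnc3c(Br)cccc32)cc1`: 2.2 mL/min/g
Compound 2 `Clc1cccc2c1nnn2CC1CC1`: 0.5 mL/min/g

Of the compounds shown here, two have been measured in an ADME assay on microsomes from liver (Rattus norvegicus, strain Wistar) for metabolic stability, tested at 2.5 uM; a lower number here means slower removal, a higher number faster removal of the compound. Compound 1 `Brc1ccc(Cn2nnc3c(Br)cccc32)cc1` gives 2.2 mL/min/g. Compound 2 `Clc1cccc2c1nnn2CC1CC1` gives 0.5 mL/min/g, the lowest of the two numbers; the gap between compound 2 and compound 1 lies beyond the scatter, so compound 2 is cleared more slowly in this assay.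

The step now followed leads from compound 2 to compound 3 `COc1cccc2c1nnn2CC1CC1`. The change is methoxy in place of chloro on an aromatic carbon. Among the measured compounds shown here, no measured pair shows this change, so its effect can only be expected, not read off. Compound 3 is expected to show a moderate rise in this assay, with a step of a 2.4-fold higher number from compound 2 to compound 3 (0.38 log units; beyond the scatter) from its parent. The estimate for compound 3 in this assay is 1.2 mL/min/g, with a range from 0.4 mL/min/g to 3.5 mL/min/g.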

Compound 3, intrinsic clearance in a liver preparation (reported as CLH), per the amount of preparation that the assay uses: 0.8 mL/min/g
Compound 3: middle estimate off by 1.5-fold (0.18 log units), on the high side; low and high end bracket the measured number.
By their numbers in this assay, from the lowest: compounds 2 and 3 (each within the scatter of the next); then compound 1.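

Read in this assay, methoxy in place of chloro on an aromatic carbon gives a 1.6-fold higher number from compound 2 to compound 3 (0.20 log units; within the scatter), the first step in the series that changes a single place. At this position of the shared core, ortho to a fused ring and meta to a fused ring, the entering methoxy brings a hydrogen-bond acceptor that chloro does not have, and yet the numbers for the two compounds cannot be told apart. Nothing available explains this outcome.

On these data alone, whether an amine, a hydroxyl or a nitrile at the same position would also stay within the scatter of compound 2 remains open. This single pair also leaves open whether methoxy in place of chloro would behave the same way with a longer chain on the shared core.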